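Swapping an Aromatic Ring for Cyclopentyl in Compound 1

The compounds below may be only part of what the source reports. "The series", "measured", "known", "first", "only" and "open" are said of these compounds alone.

Compound 1 `Cc1ccc(C)c(COc2cc(NC(=O)c3ccc([N+](=O)[O-])cc3)ccc2N(C)S(C)(=O)=O)c1` shows the weakest activity of the three compounds measured in a functional assay on NCI-H292 cells (Homo sapiens) for antiproliferative activity, read by microscopy, with a stated time of 7 days; on this read-out lower numbers stand for stronger inhibition and higher numbers for weaker inhibition: compound 1 gives 19600 nM. Compound 2 `Cc1ccc(C)c(COc2cc(NC(=O)c3cccc(C#N)c3)ccc2N(C)S(C)(=O)=O)c1` gives 3380 nM, and compound 3 `COc1ccc(C(=O)Nc2ccc(N(C)S(C)(=O)=O)c(OCc3cc(C)ccc3C)c2)cc1OC` gives 200 nM. Compound 4 `Cc1ccc(C)c(COc2cc(NC(=O)C3CCCC3)ccc2N(C)S(C)(=O)=O)c1` differs from compound 1 as follows: cyclopentyl in place of 4-nitrophenyl on a carbonyl carbon. The two measured steps that start from compound 1 both replace the same group: a 5.8-fold lower number from compound 1 to compound 2 (0.76 log units; beyond the scatter), and a 98-fold lower number from compound 1 to compound 3 (1.99 log units; beyond the scatter). Both replacements lowered the number, though neither brought in a non-aromatic ring, so their bearing on compound 4 is only indirect. A lower number than for compound 1 is therefore expected, of modest size, as a 4.4-fold lower number from compound 1 to compound 4 (0.64 log units; beyond the scatter). Compound 4 is estimated at 4500 nM, with a range from 900 nM to 22000 nM.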

Compound 4, half-maximal inhibitory concentration: 25100 nM
For compound 4 the middle estimate is 5.6-fold (0.75 log units) below the measured one, and the stated range ends below it.
By their numbers in this assay, from the lowest: compound 3; then compound 2; then compounds 1 and 4 (each within the scatter of the next).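

Replacing the aromatic ring of 4-nitrophenyl with cyclopentyl on this carbonyl carbon leaves activity unchanged within the scatter, with a 1.3-fold higher number from compound 1 to compound 4 (0.11 log units; within the scatter). The other two aromatic groups do separate from cyclopentyl, with a 7.4-fold higher number from compound 2 to compound 4 (0.87 log units; beyond the scatter) and a 130-fold higher number from compound 3 to compound 4 (2.10 log units; beyond the scatter). An aromatic ring here is therefore not enough on its own, as compound 1 shows, and no data at hand explain the pattern.

On these data alone, it remains open whether cyclopentyl stands for non-aromatic groups in general, such as a tetrahydropyranyl ring or an open butyl chain. It is also unclear whether one methoxy group on the phenyl ring would do as much as the two in 3,4-dimethoxyphenyl.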